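A few compounds are considered here, and "the series" means these few. Any claim that something is new, unique, unknown or untested is made for them only; others in the source may bear on it.

Of the compounds shown here, two carry a number so far. Compound 1 `CC(C)C(=O)NC(C(=O)N1CCC(c2ccc(Cl)cc2)CC1)C(C)C` gives 388 nM in an assay on THP-1 cells for displacement of a labelled ligand from C-C chemokine receptor type 1 (Homo sapiens); a higher number here means a weaker inhibitor, a lower number a stronger inhibitor. Compound 2 `Cc1ccccc1CCC(=O)N[C@@H](C(=O)N1CCC(c2ccc(Cl)cc2)CC1)C(C)C` gives 19 nM in this assay; this is the lower of the two numbers, and its gap to compound 1 lies beyond the usual scatter, so compound 2 is the stronger inhibitor of the pair. Compound 3 `CC(C)[C@@H](NC(=O)C1CCCC1)C(=O)N1CCC(c2ccc(Cl)cc2)CC1` has not yet been measured in this assay. It differs from compound 2 in one place: cyclopentyl in place of 2-(2-methylphenyl)ethyl on a carbonyl carbon. The cyclopentyl group brings a five-membered non-aromatic ring of carbon only where compound 2 carried a six-membered aromatic ring. Among the measured compounds shown here, no measured step tells what such a change does here. The step in this assay is expected to be a 6.3-fold higher number from compound 2 to compound 3 (0.80 log units; beyond the scatter), a loss beyond the scatter. That expected loss is smaller than the measured gap from compound 1 to compound 2. Compound 3 is estimated at 120 nM in this assay, within a range from 40 nM to 400 nM.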

Compound 3, half-maximal inhibitory concentration: 70 nM
Beside the measured number, compound 3's estimate is 1.7-fold (0.23 log units) above it; the range from low to high includes it.
By their numbers in this assay, from the lowest: compound 2; then compound 3; then compound 1.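

In this assay, cyclopentyl in place of 2-(2-methylphenyl)ethyl on a carbonyl carbon gives a 3.7-fold higher number from compound 2 to compound 3 (0.57 log units; beyond the scatter), a modest loss. This position therefore does not need the six-membered aromatic ring for a value of this order: with a five-membered non-aromatic ring of carbon only, compound 3 still gives 70 nM. Nothing at hand bears on the cause of this step.

The step changes the ring and removes the ethyl chain and the methyl group together, and the compounds shown do not separate these changes. Open at this place are 2-phenylethyl without the methyl group, phenyl directly on the carbonyl carbon, cyclohexyl, and groups carrying an amine or a carboxylic acid.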